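Trading a Benzoyl for an Acetyl on the Amide

The compounds below may be only part of what the source reports. "The series", "measured", "known", "first", "only" and "open" are said of these compounds alone.

Of the compounds shown here, three with a shared nitro-bearing core have been tested in an assay on SK-BR-3 cells for inhibition of Aromatase (Homo sapiens); a lower number here means a stronger inhibitor, a higher number a weaker inhibitor. Compound 1 `CN(c1ccc([N+](=O)[O-])cc1OCCc1ccccc1)S(C)(=O)=O` gives 520 nM in this assay. Compound 2 `CN(c1ccc([N+](=O)[O-])cc1OCc1cccc2ccccc12)S(C)(=O)=O` differs from compound 1 only in the group hanging from the ether oxygen. In this assay compound 2 gives 1170 nM. Compound 3 `O=C(Nc1ccc([N+](=O)[O-])cc1OCc1ccccc1)c1ccccc1` replaces the methylated sulfonyl nitrogen of those two with an amide nitrogen bearing a benzoyl group. Among the measured compounds shown here, for compound 3 this assay returns only a limit, > 25000 nM, which is the boundary of what the measurement can report rather than a number; it is the one value of the three that sits at that boundary (the limit of > 25000 nM in this assay, at which 1 of the 3 values shown sits).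

Compound 4 `CC(=O)Nc1ccc([N+](=O)[O-])cc1OCc1ccccc1` is the next compound, not yet measured. It keeps the amide of compound 3 and shrinks the acyl group: methyl in place of phenyl on a carbonyl carbon. For the measured compounds named here, no measured pair differs in just this way, so the size of this step has not been observed. Starting from a limit, the step from compound 3 to compound 4 can only be expected in the direction of a stronger inhibitor, if it moves at all, and its size is uncertain. The estimate for compound 4 is expected at 15000 nM, within a range from 2000 nM to 60000 nM, and the step of an at least 1.6-fold lower number from compound 3 to compound 4 (0.22 log units; that floor lies within the scatter) is expected to be modest.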

Compound 4, half-maximal inhibitory concentration: 1180 nM
For compound 4 the middle estimate is 13-fold (1.10 log units) above the measured one; measured number outside the range, below it.
By their numbers in this assay, from the lowest: compound 1; then compounds 2 and 4 (each within the scatter of the next). At a limit, above all of these: compound 3.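

In this assay, the group on this carbonyl carbon turns out to decide whether the amide gives a measurable value at all: methyl in place of phenyl produces an at least 21-fold lower number from compound 3 to compound 4 (1.32 log units; beyond the scatter). Among the compounds shown here, compound 4 is the first amide here with an actual number, so an amide nitrogen on the shared core does not by itself rule out a measurable value in this assay. The real step may be larger than the one printed, because the reading for compound 3 is a limit and not a number: the limit of > 25000 nM in this assay, at which 1 of the 4 values shown sits.

The compounds shown leave open how the value changes between the two extremes, for instance whether an ethyl or a propyl chain on the same carbonyl carbon would keep the value of compound 4 or lose it, and whether the ring of the benzoyl group could be kept if it carried an amine or a carboxylic acid. They also leave open whether the value of compound 4 would move if its ether group were exchanged for the ones carried by compound 1 and compound 2.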